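A few compounds are considered here, and "the series" means these few. Any claim that something is new, unique, unknown or untested is made for them only; others in the source may bear on it.

Measured so far:
compound 1 `O=S(=O)(Nc1ccc2oc(-c3ccccc3)nc2c1)c1ccccc1O`, which in an ADME assay on HEK293 cells (Homo sapiens) for cytotoxicity, read by resazurin assay, with a stated time of 48 h (on this read-out higher numbers stand for lower toxicity in this test and lower numbers for higher toxicity in this test), gives 33000 nM
compound 2 `O=S(=O)(Nc1ccc(-c2nc3ccccc3o2)cc1)c1cccc(Cl)c1`, for which this assay reports only a limit, > 100000 nM

Of the two measured compounds only compound 1 carries a number. Compound 2 stands at the limit of > 100000 nM in this assay, at which 1 of the 2 values shown sits, and the limit is all that is known of it. Within the data shown here, the two measured compounds differ in more than one place, so no single step between them can be read off.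

Compound 3 `Cc1ccc(S(=O)(=O)Nc2ccc(-c3nc4ccccc4o3)cc2)cc1` has not yet been measured. It differs from compound 2 in one place: 4-methylphenyl in place of 3-chlorophenyl on a sulfonyl sulfur. The sulfonamide and the shared core of compound 2 are kept. Among the measured compounds shown here, since compound 2 itself sits at the limit, there is no measured step from which to read the size of such a change. The expected step is a number no higher from compound 2 to compound 3 (the limit leaves the size open), that is none beyond the scatter. Compound 3 is therefore estimated at 100000 nM, in a range from 40000 nM to 300000 nM, with a real chance that this assay again reports only a limit.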

Compound 3, half-maximal cytotoxic concentration: 88000 nM
Compound 3: the middle estimate sits 1.1-fold (0.06 log units) above what was measured; measured number inside the range.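

In this assay compound 3 gives 88000 nM, so a compound with this shared core now carries a measured number with an aryl group on a sulfonyl sulfur. Putting 4-methylphenyl in place of 3-chlorophenyl amounts to an at least 1.1-fold lower number from compound 2 to compound 3 (0.05 log units; that floor lies within the scatter), so what can be read of this change does not go beyond the scatter. From the compounds shown here alone, its true size stays open, because compound 2 is held only by a limit: the limit of > 100000 nM in this assay, at which 1 of the 3 values shown sits.

The compounds shown leave open how an amine, a carboxylic acid or a longer chain in this place would move the number in this assay. They also leave open whether the same exchange would give a similar step on the core of compound 1, which differs from compound 2 in more than one place.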